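A few compounds are considered here, and "the series" means these few. Any claim that something is new, unique, unknown or untested is made for them only; others in the source may bear on it.

In a functional assay on HCT-116 cells (Homo sapiens) for antiproliferative activity, read by MTT assay, with a stated time of 24 h (a lower number here means a stronger inhibitor, a higher number a weaker inhibitor), all three measured compounds are weak. Compound 1 `O=C1O/C(=C\Cn2cc(Cc3ccccc3)nn2)C(OCc2ccccc2)=C1OCc1ccccc1` gives 83100 nM in this assay, and compound 3 `COC1=C(OC)C(O)(CCn2cc(-c3ccccc3)nn2)NC1=O` gives 46300 nM. Compound 2 `O=C1NC(O)(CCn2cc(C3=CCCCC3)nn2)C(OCc2ccccc2)=C1OCc1ccccc1` reaches only > 100000 nM, which is a limit of the assay and not a number. It therefore sits at the limit (the limit of > 100000 nM in this assay, at which 1 of the 3 values shown sits), the weak end of what is shown. The unmeasured compound 4 `O=C1NC(O)(CCn2cc(Cc3ccccc3)nn2)C(OCc2ccccc2)=C1OCc1ccccc1` differs from compound 2 in one place: benzyl in place of cyclohex-1-en-1-yl on an aromatic carbon. Within the data shown here, no measured pair isolates this change, but compound 1, which also carries the 4-benzyl-1H-1,2,3-triazol-1-yl group, gives 83100 nM. The step of an at least 1.1-fold lower number from compound 2 to compound 4 (0.04 log units; that floor lies within the scatter) is expected to be modest, toward stronger inhibition if anything. Compound 4 is expected to give about 90000 nM, between 40000 nM and 200000 nM.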

Compound 4, half-maximal inhibitory concentration: 51200 nM
Beside the measured number, compound 4's estimate is 1.8-fold (0.24 log units) above it, and the stated range covers the measured number.
By their numbers in this assay, from the lowest: compounds 3, 4 and 1 (each within the scatter of the next). At a limit, above all of these: compound 2.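

In this assay, the 4-benzyl-1H-1,2,3-triazol-1-yl group gives compound 4 a measured number, where the 4-(cyclohex-1-en-1-yl)-1H-1,2,3-triazol-1-yl group of compound 2 gives none. Compound 2 stands at a limit of the assay, not at a number: the limit of > 100000 nM in this assay, at which 1 of the 4 values shown sits. Going by these compounds, the change can therefore be read only as an at least 1.9-fold lower number from compound 2 to compound 4 (0.29 log units; that floor lies within the scatter), and its true size stays unknown.

The compounds shown leave open how an amine or a carboxylic acid on this aromatic carbon would read. They also leave open whether a longer chain in place of benzyl would shift the number.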